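The source may report more compounds than this note shows. Statements on the series, on what has been measured and on what is new or still open speak of the compounds shown alone.

- Compound 1 `Nc1ccccc1NC(=O)/C=C/c1ccc(CSc2ccc(Cl)cc2)cc1` gives 15.2%
- Compound 2 `Nc1ccccc1NC(=O)/C=C/c1ccc(CSc2cccc(F)c2)cc1` gives 8.56%
- Compound 3 `COc1ccc(SCc2ccc(C(=O)Nc3ccccc3N)cc2)cc1` gives 33.1%

In a functional assay on SMMC-7721 cells (Homo sapiens) for inhibition, read by CCK-8 assay, with a stated time of 72 h, tested at 2 uM (a higher number here means more inhibition of growth at the concentration tested, a lower number less inhibition of growth), compound 2 (8.56%) lies within the scatter of compound 1 (15.2%) and clearly under compound 3 (33.1%). Compound 4 `Nc1ccccc1NC(=O)/C=C/c1ccc(CSc2ccc(C(F)(F)F)cn2)cc1` is still unmeasured. It differs from compound 2 on a sulfur whose other neighbour is a saturated chain carbon (5-(trifluoromethyl)pyridin-2-yl in place of 3-fluorophenyl on a sulfur). Going by the values given here, only one measured step, also a swap of the group on a sulfur, bears on this change (a number 6.6 percentage points lower from compound 1 to compound 2 (within the scatter)) and it stays within the scatter, so no step beyond the scatter is expected in this assay here. The expected step is small (a number 4.4 percentage points higher from compound 2 to compound 4 (within the scatter)) and points slightly upward, within the scatter. The estimate for compound 4 is 13% (expected range 3% to 28%).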

Compound 4, percent growth inhibition at one concentration: 12.1%
Beside the measured number, compound 4's estimate is 0.9 percentage points above it; low and high end bracket the measured number.
By their numbers in this assay, from the lowest: compounds 2, 4 and 1 (each within the scatter of the next); then compound 3.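

In this assay, the sulfur whose other neighbour is a saturated chain carbon also accepts a 5-(trifluoromethyl)pyridin-2-yl, a ring with a hetero atom and a hydrogen-bond acceptor, without a step beyond the scatter (a number 3.5 percentage points higher from compound 2 to compound 4 (within the scatter); a number 3.1 percentage points lower from compound 1 to compound 4 (within the scatter)). The earlier step had exchanged only rings of carbon, so this range of groups on the sulfur now includes a ring with nitrogen. No measurement given here explains this result. Still open, as far as these compounds go, is whether a non-aromatic group on this sulfur, such as an aminoethyl chain or a carboxylic acid on a short chain, would give a step beyond the scatter.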